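Series notes: triazole side chain variation on the shared core

The source may report more compounds than this note shows. Statements on the series, on what has been measured and on what is new or still open speak of the compounds shown alone.

Measured so far:
- compound 1 `CCOC(=O)C1=Cc2ccccc2OC1(OCc1cn(CC(=O)Nc2ccc(C)cc2)nn1)C(F)(F)F`: 54300 nM
- compound 2 `Cc1ccc(-c2cc(COC3(C(F)(F)F)Oc4ccccc4C=C3C(=O)O)on2)cc1`: 51200 nM
- compound 3 `COc1ccc(-c2cc(COC3(C(F)(F)F)Oc4ccccc4C=C3C(=O)O)on2)cc1`: 36200 nM

In a functional assay on A549 cells (Homo sapiens) for inhibition, read by MTT assay, with a stated time of 24 h (on this read-out lower numbers stand for stronger inhibition and higher numbers for weaker inhibition), compound 1 gives the highest of the three numbers, yet its gaps to compound 2 and compound 3 both lie within the scatter, so no order among the three can be read. Going by the values given here, the only step between measured compounds, a 1.4-fold lower number from compound 2 to compound 3 (0.15 log units; within the scatter), concerns an aromatic carbon substituent and does not touch the triazole side chain.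

Compound 4 `CCOC(=O)C1=Cc2ccccc2OC1(OCc1cn(-c2ccc(C)cc2)nn1)C(F)(F)F` differs from compound 1 by 4-methylphenyl in place of ((4-methylphenyl)carbamoyl)methyl on an aromatic nitrogen. Among the compounds with values here, no measured step bears on this change, so nothing beyond the scatter is expected in this assay. The estimate for compound 4 is 50000 nM, range 20000 nM to 120000 nM, meaning an expected step of a 1.1-fold lower number from compound 1 to compound 4 (0.04 log units; within the scatter).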

Compound 4, half-maximal inhibitory concentration: 19700 nM
Compound 4: the middle estimate sits 2.5-fold (0.40 log units) above what was measured; the whole stated range lies above it.
By their numbers in this assay, from the lowest: compounds 4, 3, 2 and 1 (each within the scatter of the next, the first and the last beyond it).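

Going by these compounds alone, putting 4-methylphenyl in place of ((4-methylphenyl)carbamoyl)methyl on the aromatic nitrogen gives the first step in this assay that lies beyond the scatter, a 2.8-fold lower number from compound 1 to compound 4 (0.44 log units; beyond the scatter), though a modest one. Within the data shown here, the number at this position therefore responds to the side chain, which the earlier compounds could not show. No available evidence accounts for the step.

The change removes the amide and the methylene link together, so their shares remain unseparated. A benzyl group on the same nitrogen would help to tell them apart.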